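Compound 1 to compound 3: changing the group on nitrogen

The source may report more compounds than this note shows. Statements on the series, on what has been measured and on what is new or still open speak of the compounds shown alone.

Going by the values given here, in a functional assay on A549 cells (Homo sapiens) for antiproliferative activity, read by MTT assay, with a stated time of 72 h (a higher number here means a weaker inhibitor, a lower number a stronger inhibitor), compound 1 (`C=CC(=O)Nc1cccc(Oc2nc(Nc3ccn(C)n3)nc3c2CSCC3)c1`) gives 18600 nM, the only exact number so far. Compound 2 (`C=C(F)C(=O)Nc1cccc(Oc2nc(Nc3ccn(C)n3)nc3c2CSCC3)c1`) gives > 50000 nM, which is a limit of the assay and not a number. Among the compounds with values here, the one measured step, an at least 2.6-fold higher number from compound 1 to compound 2 (0.42 log units; beyond the scatter), lies beyond the scatter, but it sits on the double-bonded chain and leaves the group on the nitrogen untouched, so it does not size the present change. Compound 3 (`C=CC(=O)Nc1cccc(Oc2nc(Nc3ccc(OC)cc3)nc3c2CSCC3)c1`) carries 4-methoxyphenyl in place of 1-methyl-1H-pyrazol-3-yl on a nitrogen on an aromatic ring. Within the data shown here, no measured step covers this place, so a step within the scatter, leaning to a lower number in this assay, is expected, with wide uncertainty. The expected step is a 1.6-fold lower number from compound 1 to compound 3 (0.19 log units; within the scatter). Compound 3 is estimated at 12000 nM, with an expected range of 3000 nM to 42000 nM.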

Compound 3, half-maximal inhibitory concentration: 4220 nM
Compound 3: middle estimate off by 2.8-fold (0.45 log units), on the high side, within the range that was stated.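

In this assay, the group on the nitrogen is a place where the number moves: a 4.4-fold lower number from compound 1 to compound 3 (0.64 log units; beyond the scatter). Going by these compounds alone, this is the first step with an exact number at both ends, and it shows that 4-methoxyphenyl can take the place of 1-methyl-1H-pyrazol-3-yl with the rest of compound 1 unchanged and without loss in this assay. Compound 2 gives a limit of the assay and not a number, so the change on the double-bonded chain cannot be compared in size with this one: the limit of > 50000 nM in this assay, at which 1 of the 3 values shown sits.

A single step cannot separate the part played by the methoxy group from that of the ring carrying it. Going by these compounds, how a plain phenyl or a 4-carboxyphenyl on the same nitrogen would compare stays open, as does the effect of fluoro on the double-bonded chain of compound 3.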